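The compounds below may be only part of what the source reports. "The series", "measured", "known", "first", "only" and "open" are said of these compounds alone.

Compound 1 `COc1cc2nc(N3CCC(OCCO)CC3)nc(N)c2cc1OC` carries a 2-hydroxyethyl group on the oxygen of its saturated ring. In an assay on brain for displacement of a labelled ligand from Adrenergic receptor alpha-1 (Rattus norvegicus) (on this read-out higher numbers stand for weaker inhibition and lower numbers for stronger inhibition), compound 1 gives 2.2 nM, the lowest of the two numbers measured. Its nearest neighbour is compound 2 `CCOCC(OC1CCN(c2nc(N)c3cc(OC)c(OC)cc3n2)CC1)c1ccccc1`, which in this assay gives 10 nM. Going by the values given here, the one measured step, a 4.5-fold higher number from compound 1 to compound 2 (0.66 log units; beyond the scatter), comes from putting 2-ethoxy-1-phenylethyl in place of 2-hydroxyethyl on the oxygen on a saturated carbon; the larger group weakened binding by a modest amount.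

Compound 3 `COc1cc2nc(N3CCC(OCC(C)(O)c4ccccc4)CC3)nc(N)c2cc1OC` differs from compound 1 in a related way: 1-hydroxy-1-phenylethyl in place of hydroxymethyl on a saturated chain carbon bound to an oxygen on a saturated carbon. As with compound 2, a phenyl ring is added out on the chain, but here the hydroxyl that compound 1 has is kept rather than replaced by an ethoxy group. Among the compounds with values here, the step from compound 1 to compound 2 is the only guide, and it points to a weaker number when bulk is added at this place. Because that step was a 4.5-fold higher number from compound 1 to compound 2 (0.66 log units; beyond the scatter) and compound 3 keeps its hydroxyl, a smaller weakening is expected, a 2.3-fold higher number from compound 1 to compound 3 (0.36 log units; beyond the scatter). Compound 3 is therefore estimated at 5 nM in this assay, with a likely range from 1.5 nM to 16 nM.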

Compound 3, inhibition constant: 0.62 nM
The estimate for compound 3 lay 8.1-fold (0.91 log units) above the measured number; measured number outside the range, below it.
By their numbers in this assay, from the lowest: compound 3; then compound 1; then compound 2.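

In this assay, a larger group at this place does not have to weaken binding: 1-hydroxy-1-phenylethyl in place of hydroxymethyl on a saturated chain carbon bound to an oxygen on a saturated carbon moves the number the opposite way to the earlier step (a 3.5-fold lower number from compound 1 to compound 3 (0.55 log units; beyond the scatter)). A phenyl ring alone therefore does not set the direction of the change, as compound 2 and compound 3 both carry one, yet 2-hydroxy-2-phenylpropyl in place of 2-ethoxy-1-phenylethyl on an oxygen on a saturated carbon gives a large difference (a 16-fold lower number from compound 2 to compound 3 (1.21 log units; beyond the scatter)). Nothing available here explains why these two phenyl-bearing groups behave so differently.

Compound 3 differs from compound 2 both in keeping a hydroxyl and in how its chain is arranged, and it differs from compound 1 by a methyl and a phenyl ring together, so these three compounds cannot show which of these features matters. On these data alone, it also remains open how this number would respond if an amine or a carboxylic acid stood in place of the hydroxyl, or if a longer chain carried the phenyl ring.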